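Changing the amide aryl group: compound 3 to compound 4

A few compounds are considered here, and "the series" means these few. Any claim that something is new, unique, unknown or untested is made for them only; others in the source may bear on it.

Compound 3 `O=C(COc1ccc(/C=C2\SC(=O)NC2=O)cc1)Nc1ccccn1` carries a pyridin-2-yl on the amide nitrogen of the shared core. In a functional assay on HOP-62 cells (Homo sapiens) for cytotoxicity, read by sulforhodamine B assay, with a stated time of 48 h (a higher number here means a weaker inhibitor of growth, a lower number a stronger inhibitor of growth), compound 3 gives only a limit, < 100000 nM. Compound 1 `Cc1cnc(NC(=O)COc2ccc(/C=C3\SC(=O)NC3=O)cc2)s1` and compound 2 `O=C(COc1ccc(/C=C2\SC(=O)NC2=O)cc1)Nc1ncc([N+](=O)[O-])s1` share that core and differ from compound 3 only in the group on the amide nitrogen. In this assay compound 1 likewise returns a limit, < 100000 nM. Compound 2 in this assay also sits at a limit, < 100000 nM. The recorded steps are therefore a step that the two limits leave unreadable from compound 1 to compound 2, a step that the two limits leave unreadable from compound 1 to compound 3 and a step that the two limits leave unreadable from compound 2 to compound 3; none of them can be sized, and the one common fact is the limit of < 100000 nM in this assay, at which 3 of the 3 values shown sit. Compound 3 thus stands nowhere in particular among the three: all are at the same limit and no ordering can be read.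

Compound 4 `Cc1cc(NC(=O)COc2ccc(/C=C3\SC(=O)NC3=O)cc2)no1` is the next member: 5-methyl-1,2-oxazol-3-yl in place of pyridin-2-yl on an amide-type nitrogen. Among the measured compounds shown here, none of the measured steps bears on this change beyond showing that every group so far placed on the amide nitrogen has left the concentration for total growth inhibition under the limit. No direction can be expected in this assay for the step from compound 3 to compound 4, and the expected step that the limit leaves unreadable from compound 3 to compound 4 is set at nil. Compound 4 is therefore expected in this assay at 30000 nM, within 5000 nM to 100000 nM, with a fair chance that only a limit is again reported.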

Compound 4, concentration for total growth inhibition: < 100000 nM
Compound 4: only a limit was reported; the forecaster's own chance of this, stated with the estimate: 60%; the middle value lies beyond the limit too.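

The steps joining compound 4 to compound 1, compound 2 and compound 3 in this assay cannot be read, as all four compounds give limits rather than numbers: the limit of < 100000 nM in this assay, at which 4 of the 4 values shown sit. The compounds shown leave open how the four groups on the amide nitrogen order against one another in this assay, or whether they differ at all.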